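A few compounds are considered here, and "the series" means these few. Any claim that something is new, unique, unknown or untested is made for them only; others in the source may bear on it.

Compound 1 `COC(=O)/C(=C\c1ccc(OC(=O)c2c(OC)cccc2OC)cc1)Sc1ccnc2cc(Cl)ccc12` and compound 2 `COC(=O)/C(=C\c1ccc(OC(=O)c2ccc(OC)cc2OC)cc1)Sc1ccnc2cc(Cl)ccc12` share one core and differ only in the group attached to the carbonyl carbon. In a functional assay on Jurkat E6.1 cells (Homo sapiens) for cytotoxicity, read by MTT assay, with a stated time of 24 h (a lower number here means a stronger inhibitor, a higher number a weaker inhibitor), compound 1 gives 37500 nM, while compound 2 gives 10200 nM. The move a 3.7-fold lower number from compound 1 to compound 2 (0.57 log units; beyond the scatter) therefore shows that exchanging one dimethoxyphenyl pattern for another shifts the read-out beyond the scatter. Going by the values given here, on the two numbers so far, compound 2 holds the lower value, with compound 1 the only neighbour.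

Compound 3 `COC(=O)/C(=C\c1ccc(OC(=O)c2cc(OC)c(OC)c(OC)c2)cc1)Sc1ccnc2cc(Cl)ccc12` carries the change (3,4,5-trimethoxyphenyl in place of 2,4-dimethoxyphenyl on a carbonyl carbon). Among the compounds with values here, the single measured step bears on this only loosely: it concerns the same group on the carbonyl carbon and was modest in size, but the entering group here differs in both the count of methoxy groups and their arrangement, so the direction is not fixed by that step. A modest move in this assay, or none beyond the scatter, is the reasonable expectation, and compound 3 is estimated at 8000 nM, within 2500 nM to 30000 nM, which would mean a step of a 1.3-fold lower number from compound 2 to compound 3 (0.11 log units; within the scatter).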

Compound 3, half-maximal inhibitory concentration: 4570 nM
Compound 3: middle estimate off by 1.8-fold (0.24 log units), on the high side; the measured number falls inside the stated range.
By their numbers in this assay, from the lowest: compound 3; then compound 2; then compound 1.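

In this assay, the group on the carbonyl carbon goes on moving the read-out once the methoxy count changes as well as the arrangement: 3,4,5-trimethoxyphenyl in place of 2,4-dimethoxyphenyl gives a 2.2-fold lower number from compound 2 to compound 3 (0.35 log units; beyond the scatter) and in place of 2,6-dimethoxyphenyl gives an 8.2-fold lower number from compound 1 to compound 3 (0.91 log units; beyond the scatter) as the widest gap among the three compounds. Compound 3 therefore holds the lowest number, with both of its steps beyond the scatter, so the effect of this place is not confined to rearranging the methoxy groups of compound 1 and compound 2. Nothing given here accounts for why the number falls with this group.

Because the entering group differs from both earlier groups in methoxy count and arrangement at once, these steps cannot separate the two changes. The compounds shown also leave open how an unsubstituted phenyl, a hydroxyl-bearing phenyl, an amine or a carboxylic acid would behave in this place, and how changes elsewhere in the shared core, such as at the methyl ester, would compare.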